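Carbamate on Compound 2: Little Change Expected

The source may hold more compounds than are shown below. What is called first, only, known or untested is meant among the compounds shown, and "the series" means these compounds.

The shared core appears in compound 1 `CC(C)=CCC1Cc2c(O)cc(=O)n(CCCO)c2CC1(C)C`, compound 2 `CC(C)=CCC/C(C)=C/CC1Cc2c(O)cc(=O)n(CCCO)c2CC1(C)C` and compound 3 `CC(C)=CCC1Cc2c(OC(=O)Nc3cccc(F)c3)cc(=O)n(CCCO)c2CC1(C)C`. In a functional assay on PANC-1 cells (Homo sapiens) for inhibition, read by MTT assay, with a stated time of 24 h, tested at 10 uM (on this read-out higher numbers stand for more inhibition at the one concentration tested (going by the name of the read-out) and lower numbers for less inhibition), compound 1 gives 0%, compound 2 gives 0% and compound 3 gives 0%. Compound 2 stands level with both neighbours: the step of no change at the digits printed from compound 1 to compound 2 (within the scatter) and the step of no change at the digits printed from compound 1 to compound 3 (within the scatter) both lie within the scatter, so nothing in this set separates the three compounds.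

Compound 4 `COc1ccccc1NC(=O)Oc1cc(=O)n(CCCO)c2c1CC(C/C=C(\C)CCC=C(C)C)C(C)(C)C2` is not yet measured. It differs from compound 2 by (2-methoxyphenyl)carbamoyl in place of hydrogen on an oxygen on an aromatic ring. The closest measured parallel is no change at the digits printed from compound 1 to compound 3 (within the scatter), where a carbamoyl group likewise entered on the oxygen on the aromatic ring and the read-out did not move; the other measured step, no change at the digits printed from compound 1 to compound 2 (within the scatter), concerns a different place and was equally flat. With every measured step within the scatter and compound 2 itself at 0%, there is no ground in these data for expecting compound 4 to shift beyond the scatter in either direction. The step to compound 4 is therefore estimated as no change at the digits printed from compound 2 to compound 4 (within the scatter), with no direction expected. Compound 4 is expected to give about 0% in this assay, within a range from -5% to 12%.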

Compound 4, a percentage reported as inhibition, at one concentration (the size of the read-out at that concentration, not a potency): 0%
Beside the measured number, compound 4's estimate shows no gap at the digits printed; the measured number falls inside the stated range.
By their numbers in this assay, from the lowest: compounds 1, 2, 3 and 4 (each within the scatter of the next).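

In this assay, turning hydroxy into ((2-methoxyphenyl)carbamoyl)oxy gives no change at the digits printed from compound 2 to compound 4 (within the scatter), so a carbamoyl group on the oxygen on an aromatic ring has now been read on the compound carrying the 3-methylbut-2-en-1-yl extension as well as on compound 1. This reading also brings a methoxy-bearing phenyl ring to that oxygen, and the 11 heavy atoms that enter leave the read-out flat. The result therefore shows that this change gives no gain at this one concentration even on the longer-chain parent, although compound 2, at 0%, leaves no room for a loss to be seen.

The compounds shown leave open whether anything on this oxygen can raise the read-out, for instance a carbamoyl group whose phenyl ring bears a carboxylic acid or an amine, or a simple acetyl group. They also leave open whether these compounds would register at a higher concentration or over a longer exposure, and no information is available here to explain the flat read-out.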